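The source may hold more compounds than are shown below. What is called first, only, known or untested is meant among the compounds shown, and "the series" means these compounds.

Measured in a functional assay on cell membranes from liver (microsomes, Rattus norvegicus), with stated times of 10 min and 60 min; on this read-out lower numbers stand for stronger inhibition and higher numbers for weaker inhibition:
- Compound 1 `C=COC(=O)CCCCCCCCCCC(=O)OC[C@H]1Oc2ccc([C@H]3Oc4cc(O)cc(O)c4C(=O)[C@@H]3O)cc2O[C@@H]1c1ccc(O)c(OC)c1` gives 111000 nM
- Compound 2 `COc1cc([C@H]2Oc3cc([C@H]4Oc5cc(O)cc(O)c5C(=O)[C@@H]4O)ccc3O[C@@H]2COC(=O)CCCCCCCCCCC(=O)OC[C@H](O)[C@H]2OC(=O)C(O)=C2O)ccc1O` gives 30200 nM

Compound 2 holds the lower of these two numbers, and so the stronger inhibition. Compound 3 `COc1cc([C@H]2Oc3cc([C@H]4Oc5cc(O)cc(O)c5C(=O)[C@@H]4O)ccc3O[C@@H]2COC(=O)CCCCCCCCCCC(=O)OCCc2ccc(O)cc2)ccc1O` differs from it as follows: a group of 8 heavy atoms (7 carbon, 1 oxygen; one six-membered aromatic ring of carbon only) in place of a group of 10 heavy atoms (5 carbon, 5 oxygen; one five-membered non-aromatic ring with 1 hetero atom), on a saturated chain carbon bound to an oxygen next to a carbonyl group. The entering group is 4-hydroxybenzyl. Within the data shown here, only one measured step bears on this, a modest one in the same part of the molecule: a 3.7-fold lower number from compound 1 to compound 2 (0.57 log units; beyond the scatter). Among the measured compounds shown here, no measured compound carries the entering group, so the expectation is uncertain: a modest move back towards compound 1 (111000 nM), to a higher number. The expected step is a 2.0-fold higher number from compound 2 to compound 3 (0.30 log units; within the scatter). For compound 3 the estimated value is 60000 nM, with an expected range from 20000 nM to 150000 nM.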

Compound 3, half-maximal inhibitory concentration: > 1000000 nM
Compound 3 was reported as a limit (the forecaster's own chance of this, stated with the estimate: 15%); at least 16-fold (1.22 log units) between middle value and limit.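

At this place, on a saturated chain carbon bound to an oxygen next to a carbonyl group, 4-hydroxybenzyl entering gives an at least 33-fold higher number from compound 2 to compound 3 (1.51 log units; beyond the scatter) in this assay, a far larger change than the earlier modest step. With 2-(4-hydroxyphenyl)ethyl in place of vinyl there is an at least 9.0-fold higher number from compound 1 to compound 3 (0.95 log units; beyond the scatter), so a larger end group does not by itself bring a lower number. The value of compound 3 is a limit and not a number: the limit of > 1000000 nM in this assay, at which 1 of the 3 values shown sits.

Still open, as far as these compounds go, is whether a carboxylic acid or an amine at this place would give a lower number than compound 2. A longer chain between the two ester groups is also untested among the compounds shown.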